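Swapping the Chain End of Compound 2

This account rests on a few compounds, and the source may have more. Where it says the series, first, only, none or still open, it means among the compounds named here.

Compound 1 `c1ccc2c(c1)CN[C@@H](CN(CC1CCNCC1)[C@H]1CCCc3cccnc31)C2`: 86%
Compound 2 `NC(=O)N1CCN(CCCN(C[C@H]2Cc3ccccc3CN2)[C@H]2CCCc3cccnc32)CC1`: 79%

In an ADME assay on microsomes from liver (Homo sapiens) for metabolic stability, read by LC-MS, with a stated time of 10 min, tested at 0.5 uM (a lower number here means that less of the compound is left, a higher number that more of the compound is left), compound 2 stands within the usual scatter of compound 1, so these two numbers cannot be told apart. Compound 3 (`c1ccc2c(c1)CN[C@@H](CN(CCCCN1CCNCC1)[C@H]1CCCc3cccnc31)C2`) differs from compound 2 at one place ((piperazin-1-yl)methyl in place of 4-carbamoylpiperazin-1-yl on a saturated chain carbon, three bonds along the chain from an amine nitrogen): (piperazin-1-yl)methyl in place of 4-carbamoylpiperazin-1-yl on a saturated chain carbon, three bonds along the chain from an amine nitrogen. Within the data shown here, the one measured step that bears on this also exchanged a group containing a six-membered non-aromatic ring (a number 7 percentage points lower from compound 1 to compound 2 (within the scatter)) and stayed within the scatter. A single step gives no direction. The estimated step is expected to be a number 1 percentage points higher from compound 2 to compound 3 (within the scatter). Compound 3 is estimated at 80% (range 64% to 92%).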

Compound 3, percent of the compound remaining: 82%
Compound 3: the middle estimate sits 2 percentage points below what was measured; the measured number falls inside the stated range.
By their numbers in this assay, from the lowest: compounds 2, 3 and 1 (each within the scatter of the next).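

In this assay, (piperazin-1-yl)methyl in place of 4-carbamoylpiperazin-1-yl gives a number 3 percentage points higher from compound 2 to compound 3 (within the scatter), and 3-(piperazin-1-yl)propyl in place of piperidin-4-yl gives a number 4 percentage points lower from compound 1 to compound 3 (within the scatter). The three chain ends therefore cannot be told apart here, whether the piperazine carries the carbamoyl group or not. Nothing shown here explains why they read alike. On these data alone, all three chain ends contain a saturated ring, so a plain dimethylamine or a carboxylic acid at this place remains open. As far as these compounds go, a longer chain to the piperazine also remains open.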